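Bromo to methoxy on the shared core

The source may report more compounds than this note shows. Statements on the series, on what has been measured and on what is new or still open speak of the compounds shown alone.

In a functional assay on MV4-11 cells (Homo sapiens) for antiproliferative activity, with a stated time of 48 h (on this read-out lower numbers stand for stronger inhibition and higher numbers for weaker inhibition), compound 1 (`CCCNNC(=O)c1ccc(CNC(=O)c2cc3cc(Cl)ccc3[nH]2)cc1`) gives 37.7 nM and compound 2 (`CCCNNC(=O)c1ccc(CNC(=O)c2cc3cc(Br)ccc3[nH]2)cc1`) gives 66.5 nM. For the measured compounds named here, the one measured step is a 1.8-fold higher number from compound 1 to compound 2 (0.25 log units; within the scatter), with bromo in place of chloro on an aromatic carbon, and it lies within the scatter. Compound 2 therefore stands level with compound 1 on these two numbers, with no order between them.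

Compound 3 (`CCCNNC(=O)c1ccc(CNC(=O)c2cc3cc(OC)ccc3[nH]2)cc1`) carries the next change at the same aromatic carbon: methoxy in place of bromo on an aromatic carbon. In words, this is methoxy in place of bromo on an aromatic carbon. Going by the values given here, the halogen exchange is the only measured step at this place, and it bears on the new change only loosely, since neither measured compound carries methoxy. The data therefore give no direction for this change, and the reference point stays compound 2 at 66.5 nM. In this assay, no shift beyond the scatter is expected, though with wide uncertainty: the expected step is a 1.2-fold higher number from compound 2 to compound 3 (0.08 log units; within the scatter). For compound 3 the estimated value is 80 nM, with an expected range of 28 nM to 230 nM.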

Compound 3, half-maximal inhibitory concentration: 37.5 nM
Beside the measured number, compound 3's estimate is 2.1-fold (0.33 log units) above it, and the stated range covers the measured number.
By their numbers in this assay, from the lowest: compounds 3, 1 and 2 (each within the scatter of the next).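

In this assay, methoxy in place of bromo on an aromatic carbon comes with a 1.8-fold lower number from compound 2 to compound 3 (0.25 log units; within the scatter), and methoxy in place of chloro on the same carbon comes with a 1.0-fold lower number from compound 1 to compound 3 (0.00 log units; within the scatter); both steps lie within the scatter, so the three compounds stand level, with no order among them. The earlier pair compared only two halogens, whereas this result extends the level set at this carbon to a group with a carbon and an oxygen, which brings one hydrogen-bond acceptor where bromo and chloro count none, and no step beyond the scatter follows from that exchange in these three compounds. Nothing available on these compounds bears on why the three numbers sit together.

The compounds shown leave open whether a group of another kind at this carbon, such as an amine, a carboxylic acid or a longer alkoxy chain like ethoxy, would give a step beyond the scatter. They also leave open what the shared core gives with only hydrogen at this carbon, so the contribution of any group here cannot yet be read.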